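This account rests on a few compounds, and the source may have more. Where it says the series, first, only, none or still open, it means among the compounds named here.

Measured so far:
compound 1 `Cc1cc(C(=O)N2CCCCc3ccccc32)ccc1CNC(=O)Nc1ccccc1`: 130 nM
compound 2 `Cc1cc(C(=O)N2CCCCc3ccccc32)ccc1CNC(=O)N1CCC[C@H]1C(=O)OC(C)C`: 950 nM

Both compounds share a core and differ only in the group on the urea carbonyl carbon. In a functional assay on HEK293 cells for agonist activity at Vasopressin V2 receptor (Homo sapiens), read by a luciferase reporter and cAMP accumulation (a higher number here means that more compound is needed for the effect, a lower number that less compound is needed), compound 1 gives 130 nM. Compound 2 gives 950 nM and so stands at the highest of the two numbers, needing the most compound for the effect. Among the measured compounds shown here, the one step measured, a 7.3-fold higher number from compound 1 to compound 2 (0.86 log units; beyond the scatter), came from putting a pyrrolidine ester in place of the anilino group at that position.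

Compound 3 `Cc1cc(C(=O)N2CCCCc3ccccc32)ccc1CNC(=O)N1C[C@H](O)C[C@H]1C(=O)N(C)C` is not yet measured. It differs from compound 2 by 2-(dimethylcarbamoyl)-4-hydroxypyrrolidin-1-yl in place of 2-(isopropoxycarbonyl)pyrrolidin-1-yl on a carbonyl carbon. The pyrrolidine ring stays, the isopropyl ester becomes a dimethylamide, and a hydroxyl group is added to the ring. For the measured compounds named here, no measured pair tests this exact exchange; the only known step concerns the earlier replacement of the anilino group, and it was modest in size. The change from compound 2 to compound 3 is smaller in kind, so a step within the usual scatter, or only slightly beyond it in either direction, is expected.

Compound 3 is therefore estimated at 1200 nM in this assay. Its expected range runs from 400 nM to 3600 nM. The expected step is a 1.3-fold higher number from compound 2 to compound 3 (0.10 log units; within the scatter).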

Compound 3, half-maximal effective concentration: 2.3 nM
Estimate against measurement, compound 3: 520-fold (2.72 log units) above, and the stated range ends above it.
By their numbers in this assay, from the lowest: compound 3; then compound 1; then compound 2.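

In this assay, among the compounds shown here, the group on a carbonyl carbon turns out to matter far more than the earlier compounds showed: 2-(dimethylcarbamoyl)-4-hydroxypyrrolidin-1-yl in place of 2-(isopropoxycarbonyl)pyrrolidin-1-yl gives a 410-fold lower number from compound 2 to compound 3 (2.62 log units; beyond the scatter) even though the pyrrolidine ring stays and the heavy-atom count of the group is unchanged. A pyrrolidine here therefore need not fall behind the anilino group, as the earlier step alone might have suggested, for the new group gives a 57-fold lower number from compound 1 to compound 3 (1.75 log units; beyond the scatter), a step in the opposite direction to the earlier one. Nothing available here accounts for the size of these steps.

The exchange from compound 2 to compound 3 alters two features at once, the isopropyl ester becoming a dimethylamide and a hydroxyl group joining the ring, so the compounds shown leave open how much of the step belongs to each. Also open, going by these compounds, is whether the ring needs the dimethylamide at all, or whether a free carboxylic acid or a primary amide in its place, with the hydroxyl group kept, would serve as well in this assay at this position.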